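Methylsulfanyl for methoxy, tested on a second core

The source may report more compounds than this note shows. Statements on the series, on what has been measured and on what is new or still open speak of the compounds shown alone.

Compound 1 `COc1ncnc2c1c(-c1ccoc1)cn2[C@@H]1O[C@H](CO)[C@@H](O)[C@H]1O`: 1790 nM
Compound 2 `CSc1ncnc2c1c(-c1ccoc1)cn2[C@@H]1O[C@H](CO)[C@@H](O)[C@H]1O`: 5390 nM
Compound 3 `C#Cc1cn([C@@H]2O[C@H](CO)[C@@H](O)[C@H]2O)c2ncnc(OC)c12`: 1730 nM

All three values come from a functional assay on HeLa S3 cells (Homo sapiens) for antiproliferative activity, read by XTT assay, with a stated time of 72 h; on this read-out higher numbers stand for weaker inhibition and lower numbers for stronger inhibition. Compound 2 differs from compound 1 by methylsulfanyl in place of methoxy on an aromatic carbon; this change produced a 3.0-fold higher number from compound 1 to compound 2 (0.48 log units; beyond the scatter). Compound 3 differs from compound 1 in its core by ethynyl in place of furan-3-yl on an aromatic carbon, and that difference gave a 1.0-fold lower number from compound 1 to compound 3 (0.01 log units; within the scatter). Compound 4 `C#Cc1cn([C@@H]2O[C@H](CO)[C@@H](O)[C@H]2O)c2ncnc(SC)c12` has not been measured. It differs from compound 3 by methylsulfanyl in place of methoxy on an aromatic carbon, the same change at the same place as from compound 1 to compound 2. The step from compound 3 to compound 4 is therefore expected to resemble the earlier one, about a 3.0-fold higher number from compound 3 to compound 4 (0.48 log units; beyond the scatter). This expectation rests on the step of a 3.0-fold higher number from compound 1 to compound 2 (0.48 log units; beyond the scatter) and on compound 3 giving 1730 nM, within the scatter of compound 1. Compound 4 is accordingly estimated at 5200 nM, with a likely range from 2500 nM to 11000 nM.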

Compound 4, half-maximal inhibitory concentration: 110 nM
Compound 4: middle estimate off by 47-fold (1.67 log units), on the high side; measured number below the stated range.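

In this assay, methylsulfanyl in place of methoxy gave a 16-fold lower number from compound 3 to compound 4 (1.20 log units; beyond the scatter), the opposite direction from the step on the core of compound 1, so this change did not carry over from one core to the other: the same change on two cores in this assay, a 3.0-fold higher number (0.48 log units; beyond the scatter) from compound 1 to compound 2 and a 16-fold lower number (1.20 log units; beyond the scatter) from compound 3 to compound 4, 47-fold (1.68 log units) apart, beyond the scatter of two such steps Read the other way, ethynyl in place of furan-3-yl gave a 49-fold lower number from compound 2 to compound 4 (1.69 log units; beyond the scatter), although the same swap made no difference beyond the scatter when methoxy was present: the same change on two cores in this assay, a 1.0-fold lower number (0.01 log units; within the scatter) from compound 1 to compound 3 and a 49-fold lower number (1.69 log units; beyond the scatter) from compound 2 to compound 4, 47-fold (1.68 log units) apart, beyond the scatter of two such steps The two changes therefore depend on each other in these four compounds, but this single pair of cores does not show why, or how the change would behave on any other core.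

The compounds shown leave open whether a longer chain on the sulfur, such as ethylsulfanyl, would behave like methylsulfanyl. They also leave open what an amine at that place would do alongside ethynyl.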